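This account rests on a few compounds, and the source may have more. Where it says the series, first, only, none or still open, it means among the compounds named here.

Measured compounds:
- compound 1, `Cn1ccnc1[C@@H](CC(=O)O)c1ccc(OCc2cccc(-c3ccccc3S(C)(=O)=O)c2)cc1`: 23000 nM
- compound 2, `Cc1c(Cl)cccc1-c1cccc(COc2ccc([C@H](CC(=O)O)c3nccn3C)cc2)c1`: 61 nM
- compound 3, `Cn1ccnc1[C@@H](CC(=O)O)c1ccc(OCc2cccc(-c3ccccc3Cl)c2)cc1`: 43 nM

In an assay on CHO cells for agonist activity at Free fatty acid receptor 1 (Homo sapiens), read by luminescence, with a stated time of 20 s, in the presence of a further agent that is not named here (a higher number here means that more compound is needed for the effect, a lower number that less compound is needed), compound 3 holds the lowest of the three numbers. Its nearest neighbour is compound 2, a step of a 1.4-fold lower number from compound 2 to compound 3 (0.15 log units; within the scatter) that lies within the scatter, so the two cannot be ranked against each other. Compound 1 is far off: the step of a 530-fold lower number from compound 1 to compound 3 (2.73 log units; beyond the scatter) and the related step of a 380-fold lower number from compound 1 to compound 2 (2.58 log units; beyond the scatter) are both large and well beyond the scatter.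

Compound 4, `Cc1cc(F)ccc1-c1cccc(COc2ccc([C@H](CC(=O)O)c3nccn3C)cc2)c1`, differs from compound 3 by 4-fluoro-2-methylphenyl in place of 2-chlorophenyl on an aromatic carbon. Within the data shown here, the step that bears most directly on this change is the one between compound 2 and compound 3, where a 3-chloro-2-methylphenyl was swapped for a 2-chlorophenyl at the same place, and the numbers stayed within the scatter. The large steps from compound 1 concern the methylsulfonyl group, which is absent from both compound 3 and compound 4, so they offer no guide here. For compound 4 the expected step is a 1.4-fold higher number from compound 3 to compound 4 (0.14 log units; within the scatter), a move within the scatter, since the comparable swap gave a 1.4-fold lower number from compound 2 to compound 3 (0.15 log units; within the scatter). In this assay compound 4 is therefore estimated at 60 nM, with a likely range from 20 nM to 200 nM.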

Compound 4, half-maximal effective concentration: 59 nM
Beside the measured number, compound 4's estimate is 1.0-fold (0.01 log units) above it; measured number inside the range.
By their numbers in this assay, from the lowest: compounds 3, 4 and 2 (each within the scatter of the next); then compound 1.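

In this assay, the 4-fluoro-2-methylphenyl group joins the 2-chlorophenyl and 3-chloro-2-methylphenyl groups at this aromatic carbon without a separable difference, as the steps of a 1.4-fold higher number from compound 3 to compound 4 (0.14 log units; within the scatter) and a 1.0-fold lower number from compound 2 to compound 4 (0.01 log units; within the scatter) both show. Compounds 2 and 3 each carry chlorine on this ring, whereas compound 4 carries fluorine and methyl instead, so among the compounds shown chlorine on this ring is not needed to stay in this range of numbers. The step of a 390-fold lower number from compound 1 to compound 4 (2.59 log units; beyond the scatter) adds a third large gap to compound 1, which leaves the 2-(methylsulfonyl)phenyl compound alone at the far end of the series, although no evidence is at hand to explain either the gap or the close agreement of the other three.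

What the compounds leave open is where along the range of groups at this carbon the number begins to climb, since nothing lies between the three close compounds and compound 1. Going by these compounds, it also remains open whether a methoxy group, a nitrile or an amine on this ring would stay with the three close compounds or fall towards compound 1.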